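Furan-2-yl for 4-methoxyphenyl: lipophilicity notes on four compounds

The source may hold more compounds than are shown below. What is called first, only, known or untested is meant among the compounds shown, and "the series" means these compounds.

Measured in a physicochemical assay for lipophilicity, measured as octanol-water partition; a lower number here means a more polar compound, a higher number a more lipophilic compound:
compound 1 `N#Cc1c(-c2ccco2)[n+]([O-])c2ccc(C(F)(F)F)cc2[n+]1[O-]` gives 1.5
compound 2 `COc1ccc(-c2c(C#N)[n+]([O-])c3cc(C(F)(F)F)ccc3[n+]2[O-])cc1` gives 2.45
compound 3 `COc1ccc(-c2c(C#N)[n+]([O-])c3cc(C)c(C)cc3[n+]2[O-])cc1` gives 2.06

Compound 2 and compound 1 share a core and differ in one place: furan-2-yl in place of 4-methoxyphenyl on an aromatic carbon. In this assay this gave a number 0.95 log units lower from compound 2 to compound 1 (beyond the scatter). Compound 3 carries the 4-methoxyphenyl of compound 2 on a different core; the difference between the two cores is not broken down here, and the two values show compound 3 sitting lower than compound 2, beyond the scatter.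

Compound 4 `Cc1cc2c(cc1C)[n+]([O-])c(-c1ccco1)c(C#N)[n+]2[O-]` is not yet measured in this assay. It differs from compound 3 thus: furan-2-yl in place of 4-methoxyphenyl on an aromatic carbon. The place of the change is described in the same words as for the pair of compound 2 and compound 1, so this is the same change made on the core of compound 3.

For compound 4 the step from compound 3 is expected to be a number 0.96 log units lower from compound 3 to compound 4 (beyond the scatter), resting on a number 0.95 log units lower from compound 2 to compound 1 (beyond the scatter). Compound 4 is therefore estimated at 1.1, with a range from 0.7 to 1.5.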

Compound 4, partition coefficient: 1.1
For compound 4 middle estimate and measured number coincide at the digits printed; measured number inside the range.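

Furan-2-yl in place of 4-methoxyphenyl gives a number 0.96 log units lower from compound 3 to compound 4 (beyond the scatter) in this assay, and on the core of compound 2 the same change gives a number 0.95 log units lower from compound 2 to compound 1 (beyond the scatter), so between these two cores the step carries over at closely matching size. With one change on two cores, this does not show that the step would hold on any other core in the series, or for any other group at this place. Nothing at hand accounts for the size of the step or for the match between the two cores.

The compounds shown carry only furan-2-yl or 4-methoxyphenyl at this place, so it remains open how the number would move with a saturated amine, a carboxylic acid or a longer alkyl chain there. From the compounds shown here alone, the difference between the core of compound 2 and the core of compound 3 also remains unresolved into single changes, so which part of it sets their separate values stays open.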